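Swapping the 3-hydroxypropyl chain of compound 2

The source may hold more compounds than are shown below. What is called first, only, known or untested is meant among the compounds shown, and "the series" means these compounds.

Measured in a functional assay on MCF7 cells (Homo sapiens) for inhibition, read by fluorescence, with a stated time of 72 h; on this read-out lower numbers stand for stronger inhibition and higher numbers for weaker inhibition:
compound 1 `CCn1cnc2c(NC(=N)N)nc(N)nc21`: 54300 nM
compound 2 `CC(C)n1cnc2c(NC(=N)N)nc(NCCCO)nc21`: 8800 nM

Of the two, compound 2 holds the lower number and so the stronger inhibition, while compound 1 at 54300 nM stands higher, by a gap beyond the usual scatter. These two differ in more than one place, so the gap cannot be tied to any single group. Compound 3 `CC[C@H](CO)Nc1nc(NC(=N)N)c2ncn(C(C)C)c2n1` has not yet been measured. It keeps the core of compound 2 and changes one substituent (1-(hydroxymethyl)propyl in place of 3-hydroxypropyl on a nitrogen on an aromatic ring), with 1-(hydroxymethyl)propyl in place of 3-hydroxypropyl on a nitrogen on an aromatic ring. Within the data shown here, no measured pair shows this change on its own. The expectation therefore rests on compound 2 at 8800 nM as the closest measured neighbour. In this assay the estimated 1.1-fold lower number from compound 2 to compound 3 (0.04 log units; within the scatter) is expected to stay within the scatter, in neither direction. The expected value for compound 3 is 8000 nM, with an estimated range of 3000 nM to 25000 nM.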

Compound 3, half-maximal inhibitory concentration: 4500 nM
Compound 3: the middle estimate sits 1.8-fold (0.25 log units) above what was measured, within the range that was stated.
By their numbers in this assay, from the lowest: compounds 3 and 2 (each within the scatter of the next); then compound 1.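

In this assay, among these compounds, the exchange of 3-hydroxypropyl for 1-(hydroxymethyl)propyl on a nitrogen on an aromatic ring gives a 2.0-fold lower number from compound 2 to compound 3 (0.29 log units; within the scatter) and is the first reading of a change at this position on its own. At this position, then, the branched 1-(hydroxymethyl)propyl group with its one defined stereocentre keeps the number of compound 3 within the scatter of compound 2. Nothing at hand offers an explanation for this step.

The compounds shown leave open how the mirror-image form of the 1-(hydroxymethyl)propyl group would read on the same core. They also leave open whether a longer chain, or an amine or a carboxylic acid at the end of the chain in place of the hydroxyl, would move the number beyond the scatter.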